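Moving the thiophene attachment point within a shared core

This account rests on a few compounds, and the source may have more. Where it says the series, first, only, none or still open, it means among the compounds named here.

Three compounds share a six-membered non-aromatic core carrying a methyl group and a thiophene ring, and were tested in an assay on membranes from HeLa cells for displacement of a labelled ligand from adenosine receptor A3 (Homo sapiens), read by scintillation counting, with a stated time of 180 min, tested at 1 uM; a lower number here means less inhibition, a higher number more inhibition at the concentration tested (going by the name of the read-out). Compound 1 `CC1=C(C(=O)NC(C)C)C(c2cccs2)NC(=O)N1` gives 1%. Compound 2 `CC1=C(C(=O)NC(C)C)C(c2ccsc2)NC(=O)N1` gives 1%. Compound 3 `CCSC(=O)C1=C(C)NC(=O)NC1c1cccs1` gives 1%. Compound 1 and compound 2 differ by thiophen-3-yl in place of thiophen-2-yl on a saturated ring carbon, and this gave no change at the digits printed from compound 1 to compound 2 (within the scatter). The cores of compound 1 and compound 3 differ by ethylsulfanyl in place of isopropylamino on a carbonyl carbon, a change that gave no change at the digits printed from compound 1 to compound 3 (within the scatter).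

Compound 4 `CCSC(=O)C1=C(C)NC(=O)NC1c1ccsc1` has not yet been measured. It differs from compound 3 by thiophen-3-yl in place of thiophen-2-yl on a saturated ring carbon. This is the same kind of change as between compound 1 and compound 2, though the surroundings differ: in compound 3 the altered saturated ring carbon is next to the ring atom that bears a (ethylsulfanyl)carbonyl group, whereas in compound 1 that neighbour bears an isopropylcarbamoyl group. Beside no change at the digits printed from compound 1 to compound 2 (within the scatter), the expected step is a number 1 percentage points higher from compound 3 to compound 4 (within the scatter), because compound 3 gives 1% and the same kind of change left compound 1 and compound 2 level. Compound 4 is therefore estimated at 2%, between -6% and 10%.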

Compound 4, a percentage reported as inhibition, at one concentration (the size of the read-out at that concentration, not a potency): 2%
Compound 4: the middle estimate sits on the measured number at the digits printed, and the stated range covers the measured number.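

The thiophene move, thiophen-3-yl in place of thiophen-2-yl, gives a number 1 percentage points higher from compound 3 to compound 4 (within the scatter) in this assay, and this matches its earlier step on the other core: the same change on two cores in this assay, no change at the digits printed (within the scatter) from compound 1 to compound 2 and a number 1 percentage points higher (within the scatter) from compound 3 to compound 4, 1 percentage points apart, within the scatter of two such steps. Ethylsulfanyl in place of isopropylamino on the carbonyl carbon gives a number 1 percentage points higher from compound 2 to compound 4 (within the scatter), and this also matches its earlier step: the same change on two cores in this assay, no change at the digits printed (within the scatter) from compound 1 to compound 3 and a number 1 percentage points higher (within the scatter) from compound 2 to compound 4, 1 percentage points apart, within the scatter of two such steps. This shows that neither change brought out measurable inhibition on either core at the concentration tested, but with all four compounds so close to no inhibition, it does not show that either step would keep its size on a core with clear inhibition.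

The compounds shown leave open whether a phenyl ring in place of the thiophene, or an amine with a longer chain on the carbonyl carbon, would raise the inhibition in this assay. They also leave open how these four compounds would behave at other concentrations, where a real difference between them might appear.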